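This account rests on a few compounds, and the source may have more. Where it says the series, first, only, none or still open, it means among the compounds named here.

Compound 1 `CN(C)CCn1cnnc1-c1cc(Oc2ccc(NC(=O)N/N=C/c3ccc(Cl)cc3Cl)cc2F)ccn1`: 2330 nM
Compound 2 `CN(C)CCn1cnnc1-c1cc(Oc2ccc(NC(=O)N/N=C/c3ccc(O)c(O)c3)cc2F)ccn1`: > 100000 nM

Both share one core and differ only in the ring on the carbon with a double bond to nitrogen. In a functional assay on U-87MG ATCC cells (Homo sapiens) for cytotoxicity, read by MTT assay, with a stated time of 72 h (on this read-out lower numbers stand for stronger inhibition and higher numbers for weaker inhibition), compound 1 gives 2330 nM. For compound 2 the result is only a limit of this assay, > 100000 nM, so its true number is not known. The step of an at least 42-fold higher number from compound 1 to compound 2 (1.63 log units; beyond the scatter) is the only one measured here. Compound 3 `COc1ccc(/C=N/NC(=O)Nc2ccc(Oc3ccnc(-c4nncn4CCN(C)C)c3)c(F)c2)cc1O` has not been measured; it differs from compound 2 by methyl in place of hydrogen on an oxygen on an aromatic ring. Compound 2 sits at the limit of > 100000 nM in this assay, at which 1 of the 2 values shown sits, so the step of an at least 1.6-fold lower number from compound 2 to compound 3 (0.22 log units; that floor lies within the scatter) is an estimate with little anchor. Compound 3 is expected near 60000 nM, between 8000 nM and 200000 nM.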

Compound 3, half-maximal inhibitory concentration: > 100000 nM
Compound 3: no number, only a limit; the forecaster's own chance of this, stated with the estimate: 55%; middle value at least 1.6-fold (0.22 log units) away from the limit.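

In this assay compound 3 gives only a limit, > 100000 nM. The 3-hydroxy-4-methoxyphenyl ring in place of 2,4-dichlorophenyl gives an at least 42-fold higher number from compound 1 to compound 3 (1.63 log units; beyond the scatter), so the large loss seen with 3,4-dihydroxyphenyl does not need both hydroxy groups to be free. The effect of the methyl itself cannot be read, since compound 2 and compound 3 both stand at the same limit: the limit of > 100000 nM in this assay, at which 2 of the 3 values shown sit.

Going by these compounds, whether a phenyl ring carrying a single chlorine or two methoxy groups would give a readable number in this assay stays open.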